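This account rests on a few compounds, and the source may have more. Where it says the series, first, only, none or still open, it means among the compounds named here.

Measured so far:
compound 1 `CCOC(=O)c1cccc(-c2ccc(O)cc2)c1` — 100000 nM
compound 2 `CCOC(=O)c1cccc(-c2ccc([N+](=O)[O-])cc2)c1` — 95000 nM

In an assay on COS-7 cells for inhibition of patatin-like phospholipase domain-containing protein 2 (Mus musculus) (a higher number here means a weaker inhibitor, a lower number a stronger inhibitor), compound 1 gives 100000 nM. Compound 2 gives 95000 nM in this assay, so it sits within the scatter of compound 1 and the step of a 1.1-fold lower number from compound 1 to compound 2 (0.02 log units; within the scatter) carries no real difference. Compound 3 `CCOC(=O)c1cccc(-c2ccc(C)cc2)c1` is not yet measured; it differs from compound 2 by methyl in place of nitro on an aromatic carbon. Within the data shown here, the only measured step, exchanging one group at this place, changed nothing beyond the scatter, so no step beyond the scatter is expected for a 1.1-fold higher number from compound 2 to compound 3 (0.02 log units; within the scatter). Compound 3 is therefore expected at about 100000 nM, estimated between 40000 nM and 250000 nM.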

Compound 3, half-maximal inhibitory concentration: 140000 nM
Estimate against measurement, compound 3: 1.4-fold (0.15 log units) below, within the range that was stated.
By their numbers in this assay, from the lowest: compounds 2, 1 and 3 (each within the scatter of the next).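

Methyl on this aromatic carbon, para to a large group, gives no step beyond the scatter in this assay, with a 1.5-fold higher number from compound 2 to compound 3 (0.17 log units; within the scatter) and a 1.4-fold higher number from compound 1 to compound 3 (0.15 log units; within the scatter). Hydroxy, nitro and methyl therefore cannot be told apart here, and replacing nitro, with its 2 hydrogen-bond acceptors, by methyl, with 0, leaves the number within the scatter. Nothing available explains this flat result.

On these data alone, whether an amine, a carboxylic acid or a longer chain at this place would give a step beyond the scatter remains open. Also open, as far as these compounds go, is whether changes elsewhere on the shared core would do so.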